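Replacing the 4-aminocyclohexyl group of compound 2

The source may hold more compounds than are shown below. What is called first, only, known or untested is meant among the compounds shown, and "the series" means these compounds.

Measured in a functional assay on HCT-116 cells (Homo sapiens) for inhibition, with a stated time of 72 h; a higher number here means a weaker inhibitor, a lower number a stronger inhibitor:
compound 1 `NC1CCC(Nc2nc(NCc3ccc(-c4ccco4)cc3)c3ncn(C4CCCC4)c3n2)CC1`: 129 nM
compound 2 `NC1CCC(Nc2nc(NCc3ccc(-c4ccco4)nc3)c3ncn(C4CCCC4)c3n2)CC1`: 86 nM
compound 3 `NC1CCC(Nc2nc(NCc3ccc(-c4ccsc4)nc3)c3ncn(C4CCCC4)c3n2)CC1`: 145 nM

Compound 2, at 86 nM, stands level with the other two, as a 1.5-fold lower number from compound 1 to compound 2 (0.18 log units; within the scatter) and a 1.7-fold higher number from compound 2 to compound 3 (0.23 log units; within the scatter) show. The next compound is compound 4 `CC(C)(O)CNc1nc(NCc2ccc(-c3ccco3)nc2)c2ncn(C3CCCC3)c2n1`, and the change is 2-hydroxy-2-methylpropyl in place of 4-aminocyclohexyl on a nitrogen on an aromatic ring. Those two steps and a 1.1-fold higher number from compound 1 to compound 3 (0.05 log units; within the scatter) all alter a different place, so none of them bears on this swap on the nitrogen. Within the data shown here, no measured compound shows what losing the 4-aminocyclohexyl group does, so the direction is a cautious judgement and the range is wide. Expected in this assay is a 4.7-fold higher number from compound 2 to compound 4 (0.67 log units; beyond the scatter). For compound 4 the estimated value is 400 nM, with an expected range of 110 nM to 1500 nM.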

Compound 4, half-maximal inhibitory concentration: 1270 nM
Estimate against measurement, compound 4: 3.2-fold (0.50 log units) below; the range from low to high includes it.
By their numbers in this assay, from the lowest: compounds 2, 1 and 3 (each within the scatter of the next); then compound 4.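

On the nitrogen on an aromatic ring, the swap from 4-aminocyclohexyl to 2-hydroxy-2-methylpropyl gives, in this assay, a 15-fold higher number from compound 2 to compound 4 (1.17 log units; beyond the scatter). This group therefore matters far more than the changes among compounds 1, 2 and 3 at the other place, whose steps all lie within the scatter. No measurement available here explains the size of this step.

From the compounds shown here alone, the swap removes the ring and the amine together, so which of the two counts stays open. A plain cyclohexyl group would keep the ring without the amine, and a 3-aminopropyl chain would keep the amine without the ring.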